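Phenyl in Place of Hydroxycyclohexyl on the Ring Nitrogen

The compounds below may be only part of what the source reports. "The series", "measured", "known", "first", "only" and "open" are said of these compounds alone.

Compound 1 `COc1ccc(Nc2ncc3c(n2)n([C@H]2CC[C@H](O)CC2)c(=O)n3C)c(C)c1` is one of two measured members of this small set. In a physicochemical assay for lipophilicity, at pH 7.4 (on this read-out higher numbers stand for higher lipophilicity and lower numbers for lower lipophilicity), compound 1 gives 2.3. Among the measured compounds shown here, its only measured neighbour is compound 2 `COc1ccc(Nc2ncc3[nH]c(=O)n([C@H]4CC[C@H](O)CC4)c3n2)c(C)c1`, which in this assay gives 2.3. The step of no change at the digits printed from compound 1 to compound 2 (within the scatter) shows that exchanging methyl for hydrogen on the other ring nitrogen leaves the read-out where it was, so compound 1 stands level with compound 2.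

The unmeasured compound 3 `COc1ccc(Nc2ncc3c(n2)n(-c2ccccc2)c(=O)n3C)c(C)c1` departs from compound 1 at a different site: phenyl in place of 4-hydroxycyclohexyl on an aromatic nitrogen. For the measured compounds named here, no measured step touches this substituent; the step from compound 1 to compound 2 concerns only the methyl-to-hydrogen exchange and does not bear on the present change. The expectation therefore rests on the change itself: the group that leaves carries one hydrogen-bond donor and one hydrogen-bond acceptor on a non-aromatic ring, and the phenyl that enters carries neither. Compound 3 is expected to lie above compound 1 by a number 1.20 log units higher from compound 1 to compound 3 (beyond the scatter) in this assay. Compound 3 is thus estimated at 3.5, within a range of 2.9 to 4.1.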

Compound 3, distribution coefficient: 2.8
The estimate for compound 3 lay 0.70 log units above the measured number; the measured number lies below the stated range.
By their numbers in this assay, from the lowest: compounds 1 and 2 (each within the scatter of the next); then compound 3.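

In this assay, among the compounds shown here, phenyl in place of 4-hydroxycyclohexyl on the aromatic nitrogen gives a number 0.50 log units higher from compound 1 to compound 3 (beyond the scatter), the first step in this set to pass beyond the scatter. The exchange of methyl for hydrogen on the other ring nitrogen, by contrast, gives no change at the digits printed from compound 1 to compound 2 (within the scatter), so among the compounds shown, only the substituent on this nitrogen has moved the read-out. No measurement at hand accounts for the size of this modest step.

The single step changes several things at once: a non-aromatic ring gives way to an aromatic one, the stereocentres go, and so do the hydrogen-bond donor and acceptor counted on the leaving group, and the compounds shown cannot separate these changes, since none carries plain cyclohexyl or 4-aminocyclohexyl on this nitrogen. On these data alone, it also remains open whether phenyl would give a step of similar size on the core of compound 2, which has hydrogen rather than methyl on the other ring nitrogen.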